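Chloro to Cyano on an Aromatic Carbon

A few compounds are considered here, and "the series" means these few. Any claim that something is new, unique, unknown or untested is made for them only; others in the source may bear on it.

Compound 3 `O=C1CSc2cc(OCc3ccc(Cl)cc3)ccc2N1` gives 2.7 nM in an assay on isolated protein for inhibition of Amine oxidase [flavin-containing] B (Homo sapiens), read by fluorescence and spectrophotometry, with a stated time of 20 min (on this read-out higher numbers stand for weaker inhibition and lower numbers for stronger inhibition), and holds the lowest of the three numbers seen so far: compound 1 `O=C1CSc2cc(OCc3ccccc3)ccc2N1` gives 71 nM and compound 2 `O=C1CSc2cc(OCCCc3ccccc3)ccc2N1` gives 20 nM. Compound 4 `N#Cc1ccc(COc2ccc3c(c2)SCC(=O)N3)cc1` differs from compound 3 by cyano in place of chloro on an aromatic carbon. Within the data shown here, no measured step exchanges one substituent for another at that position; the only step that touches it, a 26-fold lower number from compound 1 to compound 3 (1.42 log units; beyond the scatter), shows how much the chloro alone is worth. On these data alone, whether a cyano earns as much is unknown, so the gain is expected to be partly kept. Relative to compound 3, compound 4 is expected to give a somewhat higher number, a step of a 3.0-fold higher number from compound 3 to compound 4 (0.47 log units; beyond the scatter) in this assay. Compound 4 is therefore estimated at 8 nM in this assay, within a range of 2.5 nM to 30 nM.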

Compound 4, half-maximal inhibitory concentration: 9.6 nM
Beside the measured number, compound 4's estimate is 1.2-fold (0.08 log units) below it, and the stated range covers the measured number.
By their numbers in this assay, from the lowest: compound 3; then compound 4; then compound 2; then compound 1.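

Among these compounds, at this place on the aromatic ring, chloro is not the only group that pays over hydrogen: in this assay, cyano in place of hydrogen gives a 7.4-fold lower number from compound 1 to compound 4 (0.87 log units; beyond the scatter). Yet the two groups are not interchangeable, since cyano in place of chloro gives a 3.6-fold higher number from compound 3 to compound 4 (0.55 log units; beyond the scatter), so the gain depends on which group sits there. Nothing at hand accounts for the difference between them. The compounds shown leave open whether a fluoro, a methoxy or an amine here would match chloro, and whether chloro or cyano would bring the same gain on the longer chain of compound 2.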